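The source may report more compounds than this note shows. Statements on the series, on what has been measured and on what is new or still open speak of the compounds shown alone.

In a functional assay on Jurkat cells (Homo sapiens) for inhibition, read by MTT assay, with a stated time of 72 h (a higher number here means a weaker inhibitor, a lower number a stronger inhibitor), compound 1 `COc1cccc(/C=C/C(=O)Nc2cc(OC)c(OC)c(OC)c2)c1` gives 12500 nM, compound 2 `C=C(Br)C(=O)Nc1cccc(/C=C/C(=O)Nc2ccccc2)c1` gives 5000 nM, and compound 3 `C=C(Br)C(=O)Nc1cccc(/C=C/C(=O)Nc2cccc3ccccc23)c1` gives 680 nM. Compound 2 therefore stands in the middle, with the second highest of the three numbers. It is a stronger inhibitor than compound 1 and a weaker one than compound 3, and both gaps lie beyond the usual scatter of repeated measurements.

Compound 4 `C=C(Br)C(=O)Nc1cccc(/C=C/C(=O)Nc2ccc(OC(F)(F)F)cc2)c1` is compound 2 with one change: trifluoromethoxy in place of hydrogen on an aromatic carbon, para to a large group (trifluoromethoxy in place of hydrogen on an aromatic carbon). For the measured compounds named here, no measured pair shows what this replacement does on its own, so any forecast must remain loose. Even so, the data show that the aromatic group of the amide can matter, since a different group at that place comes with a lower number in compound 3, at 680 nM. A moderate step toward a lower number is therefore expected, estimated as a 2.8-fold lower number from compound 2 to compound 4 (0.44 log units; beyond the scatter), although a result with no real change would not be surprising. The estimated value for compound 4 is 1800 nM, with an expected range from 600 nM to 5500 nM.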

Compound 4, half-maximal inhibitory concentration: 30300 nM
Estimate against measurement, compound 4: 17-fold (1.23 log units) below; the measured number lies above the stated range.
By their numbers in this assay, from the lowest: compound 3; then compound 2; then compound 1; then compound 4.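

In this assay, putting trifluoromethoxy on the aromatic carbon para to a large group, where compound 2 carries only hydrogen, gives a 6.1-fold higher number from compound 2 to compound 4 (0.78 log units; beyond the scatter) and so yields a clearly weaker inhibitor. For the compounds shown here, this is the first pair of measured compounds that differ in one place, so the effect of a single change on this ring can now be read directly rather than inferred. It shows that this position is sensitive to what it carries, and that adding a group here can cost a substantial amount of activity; no measurement of any other property accompanies this result, so the data offer no explanation for the loss.

One group at one position cannot show whether the loss is specific to trifluoromethoxy or would follow from other replacements of this hydrogen, such as a chlorine atom or an amine, either of which might raise the number or lower it. Going by these compounds, whether trifluoromethoxy on a different carbon of the same ring would give a similar step also remains open.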